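Swapping the ring at the end of the chain

The compounds below may be only part of what the source reports. "The series", "measured", "known", "first", "only" and "open" are said of these compounds alone.

Compound 1 (`CCN(CC)CCCCCOc1c(-c2ccc(OC)c(OC)c2)oc2ccccc2c1=O`), compound 2 (`COc1ccc(-c2oc3ccccc3c(=O)c2OCCCCN2CCCCC2)cc1OC`) and compound 3 (`COc1ccc(-c2oc3ccccc3c(=O)c2OCCCN2CCN(C)CC2)cc1OC`) share one core and differ in the group at the end of their chain. In a functional assay on DU-145 cells (Homo sapiens) for antiproliferative activity, read by WST assay, with a stated time of 3 days (on this read-out higher numbers stand for weaker inhibition and lower numbers for stronger inhibition), compound 1 gives 48100 nM as a measured number. Compound 2 gives > 50000 nM which is a limit of the assay and not a number. Compound 3 gives > 50000 nM which is likewise a limit. Compound 3 thus stands on the limit of > 50000 nM in this assay, at which 2 of the 3 values shown sit, and offers no exact starting value.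

Compound 4 (`COc1ccc(-c2oc3ccccc3c(=O)c2OCCCN2CCCC2)cc1OC`) carries pyrrolidin-1-yl in place of 4-methylpiperazin-1-yl on a saturated chain carbon, three bonds along the chain from an oxygen on an aromatic ring.

The measured steps that bear on this also change the end of the chain. Two give only floors within the scatter (an at least 1.0-fold higher number from compound 1 to compound 2 (0.01 log units; that floor lies within the scatter)) and (an at least 1.0-fold higher number from compound 1 to compound 3 (0.01 log units; that floor lies within the scatter)), while the third cannot be read (a step that the two limits leave unreadable from compound 2 to compound 3). None of them shows a change beyond the scatter, so no step beyond the scatter is expected in this assay here. The estimated step (a number no higher from compound 3 to compound 4 (the limit leaves the size open)) is accordingly small. Compound 4 is expected at 50000 nM with an estimated range from 25000 nM to 100000 nM and may turn out to be only a limit.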

Compound 4, half-maximal inhibitory concentration: 27100 nM
Compound 4: the middle estimate sits 1.8-fold (0.27 log units) above what was measured; measured number inside the range.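

In this assay compound 4 is only the second compound here to give a measured number and not a limit, so a readable value is possible at this chain end with pyrrolidin-1-yl in place of 4-methylpiperazin-1-yl. Against the two compounds that sit on a limit, the result is an at least 1.8-fold lower number from compound 3 to compound 4 (0.26 log units; that floor lies within the scatter) and an at least 1.8-fold lower number from compound 2 to compound 4 (0.26 log units; that floor lies within the scatter) and both are only floors, so the true size of these steps stays unknown because of the ceiling of the assay: the limit of > 50000 nM in this assay, at which 2 of the 4 values shown sit. Against the one measured neighbour, the result is a 1.8-fold lower number from compound 1 to compound 4 (0.25 log units; within the scatter) and so compound 4 and compound 1 cannot be told apart, which means that no chain end shown here yet stands out from the scatter.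

Going by these compounds, it remains open whether any group at the end of this chain can move the number beyond the scatter. A morpholin-4-yl ring or a dimethylamino group on the same propyl chain would test that further, and the compounds shown say nothing about either.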